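The source may hold more compounds than are shown below. What is called first, only, known or untested is meant among the compounds shown, and "the series" means these compounds.

Of the compounds shown here, three sharing one core have been measured in a functional assay on A549 cells (Homo sapiens) for antiproliferative activity, read by MTT assay, with a stated time of 72 h; a higher number here means a weaker inhibitor, a lower number a stronger inhibitor. Compound 1 `O=C(N/N=C/c1ccc([N+](=O)[O-])cc1)Nc1ccc(Oc2ccnc3[nH]ccc23)c(F)c1` gives 20 nM and is the strongest of the three. Compound 2 `COc1ccc(/C=N/NC(=O)Nc2ccc(Oc3ccnc4[nH]ccc34)c(F)c2)cc1` gives 3980 nM, and compound 3 `O=C(N/N=C/c1ccc([N+](=O)[O-])cc1)Nc1ccc(Oc2ccnc3[nH]ccc23)cc1` gives 2100 nM. These last two values lie within the scatter of each other, and both stand far above the value of compound 1.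

The next structure, compound 4 `CN(C)CCn1cccc1/C=N/NC(=O)Nc1ccc(Oc2ccnc3[nH]ccc23)cc1`, starts from compound 3 and makes one change, 1-(2-(dimethylamino)ethyl)-1H-pyrrol-2-yl in place of 4-nitrophenyl on a carbon with a double bond to nitrogen. The nearest measured evidence is methoxy in place of nitro, a large step of a 200-fold higher number from compound 1 to compound 2 (2.30 log units; beyond the scatter). That step was taken with fluoro present, however. Hydrogen in place of fluoro alone gave a similarly large step, a 110-fold higher number from compound 1 to compound 3 (2.02 log units; beyond the scatter), so compound 3 already sits at the level of compound 2. Among the measured compounds shown here, no measured compound carries the pyrrole group, and the data do not show whether the nitro step carries over to a compound without fluoro. In this assay, no clear shift in either direction is therefore expected, and the estimated change is a 1.1-fold lower number from compound 3 to compound 4 (0.02 log units; within the scatter). For compound 4 the expected value is 2000 nM, with an estimated range from 300 nM to 10000 nM.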

Compound 4, half-maximal inhibitory concentration: "not active" (no number reported)
The entry for compound 4 holds no number, so the estimate cannot be set against anything.
By their numbers in this assay, from the lowest: compound 1; then compounds 3 and 2 (each within the scatter of the next).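

In this assay, among the compounds shown here, compound 4 is reported only as not active, without a number, so no step from compound 3 to compound 4 can be read. Nothing shown here bears on this result. The compounds shown leave open how far compound 4 lies from compound 3, and how the 1-(2-(dimethylamino)ethyl)-1H-pyrrol-2-yl group fares with fluoro present.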